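The source may report more compounds than this note shows. Statements on the series, on what has been measured and on what is new or still open speak of the compounds shown alone.

Compound 1 `CCC(C)COc1cccc2ccc(N)nc12`: 36 nM
Compound 2 `CCCCOc1cccc2ccc(N)nc12`: 789 nM

For the measured compounds named here, compound 2 stands at the highest of the two numbers measured in an assay on cells with melanin-concentrating hormone receptor 1 (Homo sapiens) as the target, read by radioligand binding (a higher number here means a weaker inhibitor, a lower number a stronger inhibitor), so far; its only neighbour is compound 1, separated by the step of a 22-fold higher number from compound 1 to compound 2 (1.34 log units; beyond the scatter), a change of hydrogen in place of methyl on a saturated chain carbon bound to two saturated chain carbons.

Compound 3 `Nc1ccc2cccc(OCC3CC3)c2n1` differs from compound 2 by cyclopropyl in place of propyl on a saturated chain carbon bound to an oxygen on an aromatic ring. Going by the values given here, the single measured step that bears on it is a 22-fold higher number from compound 1 to compound 2 (1.34 log units; beyond the scatter), which was large and showed that removing branching from the alkoxy chain raised the number well beyond the scatter. Among the compounds with values here, compound 3 does not restore that branch; it closes the chain into a ring, a change no measured pair covers directly. A moderate drop in the number, smaller than that step, is expected for compound 3, i.e. a 3.9-fold lower number from compound 2 to compound 3 (0.60 log units; beyond the scatter). For compound 3 the estimate in this assay is 200 nM, with a range from 50 nM to 800 nM.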

Compound 3, half-maximal inhibitory concentration: > 2000 nM
Compound 3: no number, only a limit; the forecaster's own chance of this, stated with the estimate: 2%; at least 10-fold (1.00 log units) between middle value and limit.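

In this assay compound 3 gives only a limit of the assay, not a number: the limit of > 2000 nM in this assay, at which 1 of the 3 values shown sits. Replacing propyl with cyclopropyl, a group with the same 3 heavy atoms, still gives an at least 2.5-fold higher number from compound 2 to compound 3 (0.40 log units; beyond the scatter), so closing the chain into a ring moves the number in the same direction as removing the branch. The change from sec-butyl to cyclopropyl gives an at least 55-fold higher number from compound 1 to compound 3 (1.74 log units; beyond the scatter), which leaves compound 1 as the only one of the three with a low number at this position.

Going by these compounds, how far compound 3 lies beyond its limit remains open, so the size of both new steps is known only as a minimum. Also open, on these data alone, is what a longer branched chain, or an amine at the end of the chain, would give here.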